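Furoate Ester Replacing Sulfonamide on the Cyclohexyl Linker

The source may report more compounds than this note shows. Statements on the series, on what has been measured and on what is new or still open speak of the compounds shown alone.

The series shares one core, carried on a piperazine-linked cyclohexylmethyl arm, and differs only in the group on the saturated ring carbon. Compound 1 `O=c1cc(N2CCN(CC3CCC(OS(=O)(=O)c4cccnc4)CC3)CC2)sc2c([N+](=O)[O-])cc(C(F)(F)F)cc12` bears a ((pyridin-3-yl)sulfonyl)oxy group; in an ADME assay on Vero cells (Chlorocebus sabaeus) for cytotoxicity, read by MTT assay, with a stated time of 48 h (a lower number here means a stronger inhibitor, a higher number a weaker inhibitor), compound 1 reaches only the limit of > 64 ug/mL. Compound 2 `CS(=O)(=O)OC1CCC(CN2CCN(c3cc(=O)c4cc(C(F)(F)F)cc([N+](=O)[O-])c4s3)CC2)CC1` carries a (methylsulfonyl)oxy group; in this assay compound 2 likewise sits at the limit of > 64 ug/mL. Among the measured compounds shown here, compound 3 `CS(=O)(=O)NC1CCC(CN2CCN(c3cc(=O)c4cc(C(F)(F)F)cc([N+](=O)[O-])c4s3)CC2)CC1` is the methanesulfonamido analogue and gives the only number of the three, 48.5 ug/mL in this assay. The steps of an at least 1.3-fold lower number from compound 1 to compound 3 (0.12 log units; that floor lies within the scatter) and an at least 1.3-fold lower number from compound 2 to compound 3 (0.12 log units; that floor lies within the scatter) both rest on a limit of > 64 ug/mL in this assay, at which 2 of the 3 values shown sit, and lie within the scatter.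

Compound 4 `O=C(OC1CCC(CN2CCN(c3cc(=O)c4cc(C(F)(F)F)cc([N+](=O)[O-])c4s3)CC2)CC1)c1ccco1` differs from compound 3 by ((furan-2-yl)carbonyl)oxy in place of methanesulfonamido on a saturated ring carbon. The two oxygen-linked precedents, compound 1 and compound 2, both sit at the limit, so compound 4 is expected to drift back toward that limit, with an estimated step of a 1.3-fold higher number from compound 3 to compound 4 (0.12 log units; within the scatter) in this assay. The estimate for compound 4 is 64 ug/mL, within 35 ug/mL to 110 ug/mL.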

Compound 4, half-maximal inhibitory concentration: > 64 ug/mL
Compound 4 ended at the assay's limit (the forecaster's own chance of this, stated with the estimate: 55%); the middle value lies on the limit itself.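

Replacing methanesulfonamido with ((furan-2-yl)carbonyl)oxy on the saturated ring carbon gives an at least 1.3-fold higher number from compound 3 to compound 4 (0.12 log units; that floor lies within the scatter), so a carbonyl group on the oxygen now joins the two sulfonyl groups of compound 1 and compound 2 in the same outcome. In this assay all three oxygen-linked compounds end at one limit, and only the nitrogen-linked compound 3 gives a number, though the floor of its step does not separate it from compound 4: the limit of > 64 ug/mL in this assay, at which 3 of the 4 values shown sit. The steps among compound 1, compound 2 and compound 4 cannot be read, since both ends of each are limits.

Going by these compounds, how far compound 4 lies past the limit stays open. So does whether a furan-2-carboxamide, a free amine or a carboxylic acid on this ring carbon would give a readable number in this assay.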